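Enone series: swapping the dichlorophenyl arm for pentan-3-yl

The source may hold more compounds than are shown below. What is called first, only, known or untested is meant among the compounds shown, and "the series" means these compounds.

Two members of the series have been measured in a functional assay on NB-4 cells (Homo sapiens) for inhibition, read by XTT assay, with a stated time of 48 h; a higher number here means a weaker inhibitor, a lower number a stronger inhibitor. Compound 1 `CCC(/C=C(\COC(C)=O)C(=O)c1ccc(OC)cc1)CC` gives 9500 nM. Compound 2 `COc1ccc(C(=O)/C(=C/c2ccc(Cl)cc2Cl)CCOC(C)=O)cc1` gives 34800 nM, the higher of the two numbers, and its distance from compound 1 lies beyond the scatter. Among the compounds with values here, compound 1 and compound 2 differ in more than one place, so no single step between them can be read off.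

Compound 3 `CCC(/C=C(\CCOC(C)=O)C(=O)c1ccc(OC)cc1)CC` is the next compound. It differs from compound 2 by pentan-3-yl in place of 2,4-dichlorophenyl on a double-bonded chain carbon bound to a double-bonded chain carbon. Within the data shown here, no measured pair shows this change alone, so its size is not known from the data. Compound 3 also shares the pentan-3-yl arm with compound 1, whose 9500 nM is the lower of the two measured values, so the expectation is for a downward step of moderate size. The change from compound 2 to compound 3 is estimated at a 2.9-fold lower number from compound 2 to compound 3 (0.46 log units; beyond the scatter) in this assay. Compound 3 is expected to give 12000 nM, within 4000 nM to 40000 nM.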

Compound 3, half-maximal inhibitory concentration: 91100 nM
For compound 3 the middle estimate is 7.6-fold (0.88 log units) below the measured one; the measured number lies above the stated range.
By their numbers in this assay, from the lowest: compound 1; then compound 2; then compound 3.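

In this assay, with the rest of compound 2 kept, pentan-3-yl in place of 2,4-dichlorophenyl on a double-bonded chain carbon bound to a double-bonded chain carbon gives a 2.6-fold higher number from compound 2 to compound 3 (0.42 log units; beyond the scatter), so on this side chain the 2,4-dichlorophenyl arm holds the lower number. The larger step lies at the other place: acetoxymethyl in place of acetoxy on a saturated chain carbon bound to a double-bonded chain carbon gives a 9.6-fold higher number from compound 1 to compound 3 (0.98 log units; beyond the scatter), so the low number of compound 1 goes with its shorter side chain and not with pentan-3-yl alone. Nothing available explains either step.

Going by these compounds, whether 2,4-dichlorophenyl would lower the number further on the side chain of compound 1 stays open. So does the outcome of a free hydroxyl or an amine in place of the acetoxy end.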